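This account rests on a few compounds, and the source may have more. Where it says the series, first, only, none or still open, it means among the compounds named here.

Measured so far:
- compound 1, `Cn1cc(/C=C2/C(=O)Nc3ccccc32)c2cc(Nc3nccc(-c4ccc(F)cc4)n3)ccc21`: in an ADME assay on RWPE-1 cells (Homo sapiens) for cytotoxicity, read by MTT assay, with a stated time of 48 h (a lower number here means a stronger inhibitor, a higher number a weaker inhibitor), compound 1 gives 168000 nM
- compound 2, `Cn1cc(/C=C2/C(=O)Nc3ccccc32)c2cc(Nc3nccc(-c4ccc(C(F)(F)F)cc4)n3)ccc21`: in this assay compound 2 gives "not determined" (no result reported)

Going by the values given here, compound 2 therefore stands nowhere on the numbers; its only neighbour, compound 1, sits at a very weak level of cytotoxicity in this assay. Compound 3, `Cn1cc(/C=C2/C(=O)Nc3ccccc32)c2cc(Nc3nccc(-c4cccnc4)n3)ccc21`, differs from compound 2 in one place: pyridin-3-yl in place of 4-(trifluoromethyl)phenyl on an aromatic carbon. Among the compounds with values here, no step between two measured compounds is available to size this change, and the shared core is unchanged. With compound 1 as the sole anchor, the expectation for compound 3 is a value of the same order, with no shift beyond the usual scatter claimed in either direction. Compound 3 is thus expected to give about 150000 nM in this assay, somewhere between 50000 nM and 400000 nM.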

Compound 3, half-maximal inhibitory concentration: 69800 nM
The estimate for compound 3 lay 2.1-fold (0.33 log units) above the measured number; the range from low to high includes it.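

In this assay, this aromatic carbon next to the ring nitrogen is not indifferent to the group it carries: pyridin-3-yl in place of 4-fluorophenyl gives a 2.4-fold lower number from compound 1 to compound 3 (0.38 log units; beyond the scatter), a modest move towards stronger cytotoxicity. Compound 2 has no reported number, so the steps that involve it, including the loss of its 4-(trifluoromethyl)phenyl group, cannot be read. Nothing available accounts for the shift between the two measured compounds.

This single step changes two things at once, removing the fluorine and bringing a nitrogen into the ring, so it does not show which of them matters. Also open, from the compounds shown here alone, is how a plain phenyl ring, a pyridin-4-yl ring or an amine such as morpholine would behave at this carbon.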